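Trifluoromethyl in Place of Bromo: an Expected Cytotoxicity

This account rests on a few compounds, and the source may have more. Where it says the series, first, only, none or still open, it means among the compounds named here.

Three compounds were measured in a functional assay on CRL2813 cells (Homo sapiens) for cytotoxicity, read by sulforhodamine B assay, with a stated time of 5 days; on this read-out higher numbers stand for weaker inhibition and lower numbers for stronger inhibition. Compound 1 `COc1cccc(NC(=O)N[C@H]2CC[C@H](Oc3ccc(F)cc3)CC2)c1` gives 14000 nM. Compound 2 `O=C(Nc1ccccc1Br)N[C@H]1CC[C@H](Oc2ccc(F)cc2)CC1` gives 7700 nM. Compound 3 `COc1ccc(NC(=O)N[C@H]2CC[C@H](Oc3ccc(F)cc3)CC2)cc1` gives > 20000 nM, which is a limit of the assay and not a number.

Among the two numbers, compound 2 shows the lowest; the step of a 1.8-fold lower number from compound 1 to compound 2 (0.26 log units; within the scatter) is within the scatter, so compounds 1 and 2 cannot be told apart. The step of an at least 2.5-fold higher number from compound 2 to compound 3 (0.41 log units; beyond the scatter) is beyond the scatter, and the step of an at least 1.4-fold higher number from compound 1 to compound 3 (0.15 log units; that floor lies within the scatter) is not.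

Compound 4 `O=C(Nc1ccccc1C(F)(F)F)N[C@H]1CC[C@H](Oc2ccc(F)cc2)CC1` differs from compound 2 in one place: trifluoromethyl in place of bromo on an aromatic carbon. The measured steps all exchange one whole aryl group for another on the amide-type nitrogen, so none of them changes a bromo for a trifluoromethyl. They show that a 2-bromophenyl gives a number no worse than a 3-methoxyphenyl and better than a 4-methoxyphenyl, but offer no direct guide to this smaller change. A step of no clear direction, within the scatter, is therefore expected in this assay.

Compound 4 is estimated at 8000 nM, ranging from 3000 nM to 20000 nM. The expected step is a 1.0-fold higher number from compound 2 to compound 4 (0.02 log units; within the scatter).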

Compound 4, half-maximal inhibitory concentration: > 20000 nM
Compound 4: a limit, no number; the forecaster's own chance of this, stated with the estimate: 15%; middle value at least 2.5-fold (0.39 log units) away from the limit.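

In this assay, trifluoromethyl in place of bromo on an aromatic carbon, ortho to a large group, gives an at least 2.5-fold higher number from compound 2 to compound 4 (0.41 log units; beyond the scatter), so this single exchange, much smaller than swapping a whole aryl group, is enough to carry the change beyond the scatter. Compound 4 gives > 20000 nM, which is a limit of the assay and not a number. The earlier compounds compared only whole aryl groups and could not show that the group at this position matters on its own, though the true size of the step stays unknown, and the result shares its ceiling with compound 3: the limit of > 20000 nM in this assay, at which 2 of the 4 values shown sit.

With only bromo and trifluoromethyl shown at this position, nothing here tells which difference between the two groups accounts for the step, and no cause can be assigned to it. From the compounds shown here alone, how chloro, methyl or an amine at the same place would compare with compound 2 stays open, as does whether the same exchange would give a similar step on another aryl group.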